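This account rests on a few compounds, and the source may have more. Where it says the series, first, only, none or still open, it means among the compounds named here.

Compound 1 `FC(F)(F)c1ccc(CSc2nc(Nc3ccccc3)c3ccccc3n2)cc1` gives 22200 nM in a functional assay on MGC-803 cells (Homo sapiens) for cytotoxicity, read by MTT assay, with a stated time of 72 h; a lower number here means a stronger inhibitor, a higher number a weaker inhibitor. For the measured compounds named here, compound 2 `O=[N+]([O-])c1ccc(Nc2nc(SCc3ccc(C(F)(F)F)cc3)nc3ccccc23)cc1` gives 8170 nM, the lowest of the two numbers so far; the change of a 2.7-fold lower number from compound 1 to compound 2 (0.43 log units; beyond the scatter) is the only step measured. Compound 3 `FC(F)(F)c1ccc(CSc2nc(Nc3ccc(C(F)(F)F)cc3)c3ccccc3n2)cc1` is not yet measured and differs from compound 2 by trifluoromethyl in place of nitro on an aromatic carbon. Going by the values given here, no measured step replaces a nitro group, so the one step that bears on it is the hydrogen-to-nitro gain from compound 1 to compound 2. Compound 3 is therefore expected to land between its two neighbours, a step of a 1.5-fold higher number from compound 2 to compound 3 (0.17 log units; within the scatter), estimated at 12000 nM within 5000 nM to 30000 nM.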

Compound 3, half-maximal inhibitory concentration: 6170 nM
The estimate for compound 3 lay 1.9-fold (0.29 log units) above the measured number; the measured number falls inside the stated range.
By their numbers in this assay, from the lowest: compounds 3 and 2 (each within the scatter of the next); then compound 1.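

In this assay, trifluoromethyl in place of nitro on this aromatic carbon gives a 1.3-fold lower number from compound 2 to compound 3 (0.12 log units; within the scatter) and so leaves the two groups indistinguishable here. Nitro is therefore not the only group that improves on hydrogen at this place, since trifluoromethyl in place of hydrogen gives a 3.6-fold lower number from compound 1 to compound 3 (0.56 log units; beyond the scatter) as a second gain. Nothing measured here explains either gain.

On these data alone, whether an amine or a carboxylic acid at the same place would also lower the number remains open. So does whether either gain would hold on another carbon of that ring.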